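Extending the hydroxyalkyl chain on compound 3

The compounds below may be only part of what the source reports. "The series", "measured", "known", "first", "only" and "open" are said of these compounds alone.

Three compounds share a spiro core carrying a phenyl group and an aroyl piperidine. Compound 1 `CC(C)(C)OC(=O)NCC1CCCN(C(=O)CN2CN(c3ccccc3)C3(CCN(C(=O)c4ccc(C5CCCCC5)cc4)CC3)C2=O)C1` and compound 2 `CC(C)(C)OC(=O)NC1CCCN(C(=O)CN2CN(c3ccccc3)C3(CCN(C(=O)c4ccc(C5CCCCC5)cc4)CC3)C2=O)C1` differ only in that compound 2 carries (tert-butoxycarbonyl)amino in place of ((tert-butoxycarbonyl)amino)methyl on a saturated ring carbon; in an assay on HEK293 cells for displacement of a labelled ligand from NPC1-like intracellular cholesterol transporter 1 (Homo sapiens) (on this read-out higher numbers stand for weaker inhibition and lower numbers for stronger inhibition), compound 1 gives 3800 nM and compound 2 gives 4400 nM, a change described as a 1.2-fold higher number from compound 1 to compound 2 (0.06 log units; within the scatter). Compound 3 `CC(C)(C)c1ccc(C(=O)N2CCC3(CC2)C(=O)N(CC(=O)NCCO)CN3c2ccccc2)cc1` is built on the same core but carries a hydroxyethyl amide chain and a tert-butyl group on the aroyl ring; in this assay compound 3 gives 1000 nM, the lowest number of the three.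

Compound 4 `CC(C)(C)c1ccc(C(=O)N2CCC3(CC2)C(=O)N(CC(=O)NCCCCO)CN3c2ccccc2)cc1` differs from compound 3 as follows: 2-hydroxyethyl in place of hydroxy on a saturated chain carbon, two bonds along the chain from an amide-type nitrogen. Within the data shown here, no measured step concerns lengthening of this chain; the only step available, from compound 1 to compound 2, touches a different position and lies within the scatter. Compound 4 is therefore expected to stay close to compound 3, with a step of about no change at the digits printed from compound 3 to compound 4 (within the scatter), and its estimated value in this assay is 1000 nM, ranging from 450 nM to 2500 nM.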

Compound 4, half-maximal inhibitory concentration: 19200 nM
Compound 4: the middle estimate sits 19-fold (1.28 log units) below what was measured; measured number outside the range, above it.
By their numbers in this assay, from the lowest: compound 3; then compounds 1 and 2 (each within the scatter of the next); then compound 4.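

Putting 2-hydroxyethyl in place of hydroxy on a saturated chain carbon, two bonds along the chain from an amide-type nitrogen, gives a 19-fold higher number from compound 3 to compound 4 (1.28 log units; beyond the scatter) in this assay, so this chain is sensitive to its length, something the earlier step at another position could not show. The group that leaves and the group that enters carry the same hydrogen-bond donor and acceptor counts and no net charge, and the change amounts to (2-hydroxyethyl)amino becoming (4-hydroxybutyl)amino. No measurement at hand explains the large rise.

The compounds shown leave open whether the (3-hydroxypropyl)amino chain, of intermediate length, would sit nearer compound 3 or compound 4. They also leave open whether the terminal hydroxy matters at all, which a plain butyl chain, or an amine or carboxylic acid at the chain end, would test.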